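Pyrazole capping on the biphenyl amide series

The source may report more compounds than this note shows. Statements on the series, on what has been measured and on what is new or still open speak of the compounds shown alone.

Measured compounds in a functional assay on MV4-11 cells (Homo sapiens) for antiproliferative activity, with a stated time of 6 days, tested at 1.56 uM; on this read-out lower numbers stand for a weaker effect and higher numbers for a stronger effect at the one concentration tested:
compound 1 `CNC(=O)N1CCCc2ccc(NC(=O)c3ccc(-c4ccccc4)cc3)cc21` gives 19.7%
compound 2 `CNC(=O)N1CCCc2ccc(NC(=O)c3ccc(-c4cnn(S(C)(=O)=O)c4)cc3)cc21` gives 4.5%
compound 3 `CNC(=O)N1CCCc2ccc(NC(=O)c3ccc(-c4cc[nH]n4)cc3)cc21` gives 92.5%

Compound 3 stands highest of the three numbers. Its nearest neighbour is compound 1, with a number 72.8 percentage points higher from compound 1 to compound 3 (beyond the scatter); the furthest is compound 2, with a number 88 percentage points higher from compound 2 to compound 3 (beyond the scatter). Both steps lie beyond the scatter, so compound 3 is the strongest of the measured set in this assay.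

Compound 4 `CNC(=O)N1CCCc2ccc(NC(=O)c3ccc(-c4ccn(C(C)=O)n4)cc3)cc21` differs from compound 3 in one place: acetyl in place of hydrogen on an aromatic nitrogen. For the measured compounds named here, the step most closely bearing on it is the one from compound 2 to compound 3, where removing a group from the pyrazole nitrogen and moving the attachment point went with a number 88 percentage points higher from compound 2 to compound 3 (beyond the scatter). Compound 1, with a plain phenyl and no ring nitrogen, sits low as well, per a number 72.8 percentage points higher from compound 1 to compound 3 (beyond the scatter). Among the measured compounds only the free pyrazole nitrogen-hydrogen of compound 3 coincides with a high number. Covering that nitrogen with acetyl is therefore expected to cost much of the effect, though the acetyl is not the methylsulfonyl of compound 2 and the attachment point differs, so the size is uncertain.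

Compound 4 is expected to show a number 62.5 percentage points lower from compound 3 to compound 4 (beyond the scatter) in this assay. The estimate for compound 4 is 30%, ranging from 5% to 75%.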

Compound 4, a percentage reported as inhibition, at one concentration (the size of the read-out at that concentration, not a potency): 35.8%
Compound 4: middle estimate off by 5.8 percentage points, on the low side; measured number inside the range.
By their numbers in this assay, from the lowest: compound 2; then compound 1; then compound 4; then compound 3.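

In this assay, for the compounds shown here, acetyl in place of hydrogen on the aromatic nitrogen gives a number 56.7 percentage points lower from compound 3 to compound 4 (beyond the scatter) and is the only step so far that changes that nitrogen while keeping the 1H-pyrazol-3-yl attachment, so the free nitrogen-hydrogen of compound 3 now has a direct one-place comparison; every earlier step also changed the ring or the attachment point. The loss is not complete, since the 1-acetyl-1H-pyrazol-3-yl group still gives a number 31.3 percentage points higher from compound 2 to compound 4 (beyond the scatter) against the 1-(methylsulfonyl)-1H-pyrazol-4-yl group and a number 16.1 percentage points higher from compound 1 to compound 4 (beyond the scatter) against phenyl, which places compound 4 in an intermediate position among the four compounds. No measurement is available that explains the drop on acetylation.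

On these data alone, whether any group on this nitrogen lowers the number to a similar extent remains open, as a methyl or a longer chain there would test whether the result is specific to acetyl. The contributions of the methylsulfonyl group and the attachment point to the low number of compound 2 also remain unseparated, and a 1-(methylsulfonyl)-1H-pyrazol-3-yl group or a 1H-pyrazol-4-yl group would address that question.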